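A few compounds are considered here, and "the series" means these few. Any claim that something is new, unique, unknown or untested is made for them only; others in the source may bear on it.

In a functional assay on NCI-H460 cells (Homo sapiens) for antiproliferative activity, with a stated time of 72 h (on this read-out higher numbers stand for weaker inhibition and lower numbers for stronger inhibition), compound 1 `CCCC#Cc1cc([C@@H]2O[C@H](CO)[C@@H](O)[C@H]2O)n2ncnc(N)c12` gives 400 nM and compound 2 `Nc1ncnn2c([C@@H]3O[C@H](CO)[C@@H](O)[C@H]3O)cc(C#Cc3ccc(F)cc3)c12` gives 79400 nM while compound 3 `Nc1ncnn2c([C@@H]3O[C@H](CO)[C@@H](O)[C@H]3O)cc(C#Cc3ccccc3)c12` gives 38500 nM as the second highest of the three numbers. Compound 4 `Nc1ncnn2c([C@@H]3O[C@H](CO)[C@@H](O)[C@H]3O)cc(-c3ccc(F)cc3F)c12` has 2,4-difluorophenyl in place of 2-phenylethynyl on an aromatic carbon of the shared core (2,4-difluorophenyl in place of 2-phenylethynyl on an aromatic carbon). Among the compounds with values here, no measured step makes this swap. Two steps on the triple-bonded carbon are large, namely a 96-fold higher number from compound 1 to compound 3 (1.98 log units; beyond the scatter) and a 200-fold higher number from compound 1 to compound 2 (2.30 log units; beyond the scatter) and both start from propyl, a group absent from the change at hand. Only a 2.1-fold lower number from compound 2 to compound 3 (0.31 log units; beyond the scatter) concerns fluoro, and it is modest. No step beyond the scatter is therefore expected in this assay and the estimated step, on thin evidence, is a 1.5-fold lower number from compound 3 to compound 4 (0.19 log units; within the scatter) at most a loose guide. Compound 4 is expected at 25000 nM (estimated range 4000 nM to 100000 nM).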

Compound 4, half-maximal inhibitory concentration: 93300 nM
Estimate against measurement, compound 4: 3.7-fold (0.57 log units) below; the range from low to high includes it.
By their numbers in this assay, from the lowest: compound 1; then compound 3; then compounds 2 and 4 (each within the scatter of the next).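

In this assay, the triple bond can go without much further loss once an aromatic ring sits at this position: 2,4-difluorophenyl gives a 2.4-fold higher number from compound 3 to compound 4 (0.38 log units; beyond the scatter) as a modest step and a 1.2-fold higher number from compound 2 to compound 4 (0.07 log units; within the scatter) within the scatter. Replacing pent-1-yn-1-yl gives a 230-fold higher number from compound 1 to compound 4 (2.37 log units; beyond the scatter) as a large step, so all three aromatic groups lie far from the open chain of compound 1. No measurement here offers an explanation for these steps.

Still open, as far as these compounds go, is whether a longer chain such as hexynyl, or a chain ending in an amine, would keep the potency of compound 1.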